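The compounds below may be only part of what the source reports. "The series", "measured", "known", "first", "only" and "open" are said of these compounds alone.

Compound 3 (`COc1ccc(/C=C/C(=O)c2ccc(OC)c3c2OC(C)(C)C=C3)cn1`) reads > 10000 nM in a functional assay on HepG2 cells (Homo sapiens) for antiproliferative activity, read by MTT assay, with a stated time of 24 h (on this read-out lower numbers stand for stronger inhibition and higher numbers for weaker inhibition), and this value is a limit. Compound 1 (`COc1ccc(C(=O)/C=C/c2ccc(Br)cc2)c2c1C=CC(C)(C)O2`) reads > 10000 nM, also a limit. Among the measured compounds shown here, compound 2 (`COc1ccc(C(=O)/C=C/c2cccc([N+](=O)[O-])c2)c2c1C=CC(C)(C)O2`) gives 2830 nM, the only true number so far.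

Compound 4 (`COc1ccc(C(=O)/C=C/c2ccccn2)c2c1C=CC(C)(C)O2`) differs from compound 3 by pyridin-2-yl in place of 6-methoxypyridin-3-yl on a double-bonded chain carbon bound to a double-bonded chain carbon.

Changes at this same place gave an at least 3.5-fold lower number from compound 1 to compound 2 (0.54 log units; beyond the scatter), an at least 3.5-fold higher number from compound 2 to compound 3 (0.54 log units; beyond the scatter) and a step that the two limits leave unreadable from compound 1 to compound 3. With compound 1 and compound 3 both at the limit of > 10000 nM in this assay, at which 2 of the 3 values shown sit, no step beyond the scatter is expected in this assay. The expected step is an at least 1.1-fold lower number from compound 3 to compound 4 (0.04 log units; that floor lies within the scatter). For compound 4 the estimated value is 9000 nM, with an expected range of 2500 nM to 30000 nM.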

Compound 4, half-maximal inhibitory concentration: 5760 nM
The estimate for compound 4 lay 1.6-fold (0.19 log units) above the measured number, and the stated range covers the measured number.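

In this assay compound 4 is the second compound at this place with a true number, and the first with a ring holding a hetero atom; the 6-methoxypyridin-3-yl ring gave only a limit. Pyridin-2-yl in place of 6-methoxypyridin-3-yl or 4-bromophenyl gives an at least 1.7-fold lower number from compound 3 to compound 4 (0.23 log units; that floor lies within the scatter) and an at least 1.7-fold lower number from compound 1 to compound 4 (0.23 log units; that floor lies within the scatter), both floors only. Pyridin-2-yl in place of 3-nitrophenyl gives a 2.0-fold higher number from compound 2 to compound 4 (0.31 log units; beyond the scatter), so the 3-nitrophenyl group stays ahead of it at this place.

Open, on these data alone, is how unsubstituted phenyl or pyridin-3-yl would read here. Also open, as far as these compounds go, is how a ring carrying an amine or a carboxylic acid would read.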